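Ring-nitrogen benzyl versus phenyl on the arylidene succinimide core

This account rests on a few compounds, and the source may have more. Where it says the series, first, only, none or still open, it means among the compounds named here.

The three measured compounds share one core and differ at the two nitrogens. Compound 1 `CCOc1ccc(NC(=O)c2cccc(/C=C3\CC(=O)N(Cc4ccccc4)C3=O)c2)cc1` carries benzyl on the ring nitrogen and a 4-ethoxyphenyl amide; in an ADME assay on SW480 cells (Homo sapiens) for cytotoxicity, read by MTT assay, with a stated time of 72 h (a lower number here means a stronger inhibitor, a higher number a weaker inhibitor), compound 1 gives 73200 nM. Compound 2 `CCCCNC(=O)c1cccc(/C=C2\CC(=O)N(Cc3ccccc3)C2=O)c1` keeps the benzyl but has a butyl amide. For compound 2 the result in this assay is a limit of the assay, > 100000 nM. For the measured compounds named here, the only step between compounds differing in one place is an at least 1.3-fold higher number from compound 1 to compound 2 (0.13 log units; that floor lies within the scatter), and it stays within the scatter. Compound 3 `O=C(Nc1ccc(Cl)cc1)c1cccc(/C=C2\CC(=O)N(c3ccccc3)C2=O)c1` has phenyl on the ring nitrogen and a 4-chlorophenyl amide. For compound 3 the result in this assay is again a limit, > 100000 nM. So compound 3 stands at the floor of what the series shows: two of the three values sit at the limit (the limit of > 100000 nM in this assay, at which 2 of the 3 values shown sit), and the one numerical value, that of compound 1, lies close beneath it.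

Compound 4 `O=C(Nc1ccc(Cl)cc1)c1cccc(/C=C2\CC(=O)N(Cc3ccccc3)C2=O)c1` differs from compound 3 by benzyl in place of phenyl on an amide-type nitrogen in a ring. Going by the values given here, no measured step touches the ring nitrogen, so nothing measured bears directly on this change. Among the compounds with values here, compound 1, which already carries benzyl there with an aryl amide, gives 73200 nM, and the sole measured step, an at least 1.3-fold higher number from compound 1 to compound 2 (0.13 log units; that floor lies within the scatter), lies within the scatter. No movement beyond the scatter is therefore expected in this assay. Compound 4 is expected near 90000 nM, between 40000 nM and 200000 nM. This estimate corresponds to an at least 1.1-fold lower number from compound 3 to compound 4 (0.04 log units; that floor lies within the scatter), with a real chance that only a limit is reported.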

Compound 4, half-maximal inhibitory concentration: > 100000 nM
Compound 4 was reported as a limit; the forecaster's own chance of this, stated with the estimate: 55%; middle value at least 1.1-fold (0.04 log units) away from the limit.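

Compound 4 brings benzyl on the ring nitrogen together with the 4-chlorophenyl amide, and in this assay compound 4 is a limit, as compound 3 is, so benzyl in place of phenyl gives no readable change here; the steps that join compound 4 to compound 3 and to compound 2 link two limits and cannot be read. For the compounds shown here, the one readable step, chloro in place of ethoxy on an aromatic carbon, is an at least 1.3-fold higher number from compound 1 to compound 4 (0.13 log units; that floor lies within the scatter), so this change on the aryl amide does not set compound 1 and compound 4 apart. Benzyl on the ring nitrogen therefore does not by itself yield a numerical value, compound 1 being the only compound shown that has one, and the series now sits almost entirely at one end of the assay: the limit of > 100000 nM in this assay, at which 3 of the 4 values shown sit.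

On these data alone, whether the ring nitrogen matters at all in this assay stays open, as the benzyl and phenyl pair gives no size. As far as these compounds go, whether an aminoethyl chain on the amide-type nitrogen or a carboxylic acid on the benzyl group would bring a compound to a numerical value also stays open.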